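Changing the Aryl Group at the Far End of Compound 2

The source may hold more compounds than are shown below. What is called first, only, known or untested is meant among the compounds shown, and "the series" means these compounds.

Compound 1 `CN1[C@@H]2c3[nH]c4ccccc4c3C[C@H]1[C@H](C#N)N1[C@@H](CNC(=O)c3cc4ccccc4s3)c3[nH]c4ccccc4c3C[C@@H]21` gives 500 nM in a functional assay on HCT-116 cells (Homo sapiens) for cytotoxicity, read by MTT assay, with a stated time of 72 h; on this read-out lower numbers stand for stronger inhibition and higher numbers for weaker inhibition.
Compound 2 `CN1[C@@H]2c3[nH]c4ccccc4c3C[C@H]1[C@H](C#N)N1[C@@H](CNC(=O)/C=C/c3cccc(C(F)(F)F)c3)c3[nH]c4ccccc4c3C[C@@H]21` gives 610 nM in this assay.

Compound 2 has the highest of the two numbers in this assay, but only by a 1.2-fold higher number from compound 1 to compound 2 (0.09 log units; within the scatter), a gap inside the usual scatter, so the two compounds cannot be ranked. Compound 3 `COc1ccc(/C=C/C(=O)NC[C@H]2c3[nH]c4ccccc4c3C[C@H]3[C@H]4c5[nH]c6ccccc6c5C[C@@H]([C@H](C#N)N23)N4C)cc1` differs from compound 2 by 4-methoxyphenyl in place of 3-(trifluoromethyl)phenyl on a double-bonded chain carbon bound to a double-bonded chain carbon. Within the data shown here, no measured step touches this ring; the single recorded step altered a different part of the molecule and stayed within the scatter. A step of that kind, within the scatter, is therefore expected from compound 2 to compound 3, a 1.0-fold lower number from compound 2 to compound 3 (0.01 log units; within the scatter). Compound 3 is expected to give 600 nM in this assay, within a range of 250 nM to 1500 nM.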

Compound 3, half-maximal inhibitory concentration: 5060 nM
Compound 3: the middle estimate sits 8.4-fold (0.93 log units) below what was measured, and the stated range ends below it.
By their numbers in this assay, from the lowest: compounds 1 and 2 (each within the scatter of the next); then compound 3.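

Among these compounds, the aryl ring on the ethenyl chain matters in this assay: 4-methoxyphenyl in place of 3-(trifluoromethyl)phenyl gives an 8.3-fold higher number from compound 2 to compound 3 (0.92 log units; beyond the scatter), the first step here beyond the scatter. Against the 1-benzothiophen-2-yl end group there is a 10-fold higher number from compound 1 to compound 3 (1.01 log units; beyond the scatter), so the match seen earlier does not extend to every 2-arylethenyl group. Nothing available explains this drop. The group and its place on the ring changed together, and the compounds shown do not separate the two. Going by these compounds, how a plain phenyl ring or a ring carrying an amine would behave also stays open.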